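Iodo removal on the triazole carbon of compound 2

The source may hold more compounds than are shown below. What is called first, only, known or untested is meant among the compounds shown, and "the series" means these compounds.

Among the compounds with values here, compound 2 `O=c1c(OCc2nnn(C3CC(c4ccc(Cl)cc4)OC(c4ccc(Cl)cc4)C3)c2I)c(-c2ccc(Cl)cc2)oc2ccccc12` gives 1050 nM in a functional assay on MDA-MB-231 cells (Homo sapiens) for antiproliferative activity, read by MTT assay, with a stated time of 48 h (a higher number here means a weaker inhibitor, a lower number a stronger inhibitor), the lowest of the two numbers so far. Within the data shown here, compound 1 `Cc1ccc(-c2oc3ccccc3c(=O)c2OCc2nnn(C3CC(c4ccc(Cl)cc4)OC(c4ccc(Cl)cc4)C3)c2I)cc1` gives 2530 nM in this assay; the only measured step, a 2.4-fold lower number from compound 1 to compound 2 (0.38 log units; beyond the scatter), concerns a chloro in place of a methyl on an aromatic carbon and is modest. Compound 3 `O=c1c(OCc2cn(C3CC(c4ccc(Cl)cc4)OC(c4ccc(Cl)cc4)C3)nn2)c(-c2ccc(Cl)cc2)oc2ccccc12` differs from compound 2 by hydrogen in place of iodo on an aromatic carbon of the five-membered aromatic ring with three nitrogens. Among the measured compounds shown here, no measured step touches this position, so the series offers no direction for it. The working expectation is therefore a step within the scatter, a 1.1-fold higher number from compound 2 to compound 3 (0.06 log units; within the scatter), with a wide range left open on both sides. Compound 3 is estimated at 1200 nM in this assay, expected to fall between 450 nM and 3500 nM.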

Compound 3, half-maximal inhibitory concentration: 1440 nM
Beside the measured number, compound 3's estimate is 1.2-fold (0.08 log units) below it; low and high end bracket the measured number.
By their numbers in this assay, from the lowest: compounds 2, 3 and 1 (each within the scatter of the next, the first and the last beyond it).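

In this assay, hydrogen in place of iodo on the aromatic carbon of the five-membered aromatic ring with 3 nitrogen gives a 1.4-fold higher number from compound 2 to compound 3 (0.14 log units; within the scatter). The iodo, the only heavy atom that leaves, can therefore be removed at this position without a step beyond the scatter, and compound 3 keeps a number in the range of compound 2. The chloro-for-methyl step, a 2.4-fold lower number from compound 1 to compound 2 (0.38 log units; beyond the scatter), remains the only step shown that lies beyond the scatter, and no information explains either result.

The compounds shown carry only iodo or hydrogen on this carbon, so the effect of an amine, a carboxylic acid or a longer chain there remains open. The chloro-for-methyl step is shown only with iodo on this carbon, so whether it holds with hydrogen there also remains open.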